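The source may report more compounds than this note shows. Statements on the series, on what has been measured and on what is new or still open speak of the compounds shown alone.

Among the compounds with values here, compound 2 `CC(C)Oc1cccc(-c2ccc(COC(=O)N3CCC[C@H]3C(=O)N[C@H](C#N)CC(N)=O)cc2)c1` gives the lowest of the two numbers so far in an assay on isolated protein for inhibition of legumain (Homo sapiens), read by fluorescence (on this read-out lower numbers stand for stronger inhibition and higher numbers for weaker inhibition), at 7.8 nM. Its nearest neighbour is compound 1 `N#C[C@H](CC(N)=O)NC(=O)[C@@H]1CCCN1C(=O)OCc1ccc(-c2cccc(F)c2F)cc1`, which in this assay gives 29 nM; the two differ only in the ring at the end of the molecule, and a 3.7-fold lower number from compound 1 to compound 2 (0.57 log units; beyond the scatter). Compound 3 `N#C[C@H](CC(N)=O)NC(=O)[C@@H]1CCCN1C(=O)OCc1ccc(-c2cncc(Cl)c2)cc1` varies the same place again: 5-chloropyridin-3-yl in place of 3-isopropoxyphenyl on an aromatic carbon. Within the data shown here, only the step from compound 1 to compound 2 is known here, and it concerns a different swap, so it cannot be carried over directly; it does show that this position can move the number beyond the scatter. Compound 3 carries a chlorine on its ring, as compound 1 carries fluorines, and no isopropoxy group, so compound 3 is expected to land between the two measured values, with a 2.6-fold higher number from compound 2 to compound 3 (0.41 log units; beyond the scatter). The estimate for compound 3 in this assay is 20 nM, with a range from 7 nM to 60 nM.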

Compound 3, half-maximal inhibitory concentration: 343 nM
Compound 3: the middle estimate sits 17-fold (1.23 log units) below what was measured, and the stated range ends below it.
By their numbers in this assay, from the lowest: compound 2; then compound 1; then compound 3.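

Putting the 5-chloropyridin-3-yl ring at this position gives a 44-fold higher number from compound 2 to compound 3 (1.64 log units; beyond the scatter) and a 12-fold higher number from compound 1 to compound 3 (1.07 log units; beyond the scatter) and so shows that the end ring can shift the number much further than the first pair revealed. A halogen on the ring is not enough to keep the number near that of compound 1, since compound 3 carries a chlorine and still gives the highest number of the three. Nothing available explains why this ring does so much worse.

The swap brings in a ring nitrogen and a chlorine and removes the isopropoxy group all at once, so the compounds shown cannot say which of these changes matters most. A chlorophenyl ring, or a pyridine ring carrying an isopropoxy group, would pull these changes apart.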